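Aryl replacement on the shared core: toward the 3-methylfuran-2-yl analog

A few compounds are considered here, and "the series" means these few. Any claim that something is new, unique, unknown or untested is made for them only; others in the source may bear on it.

Compounds measured so far:
compound 1 `c1cncc(-c2ccccc2OCC2=NCCN2)c1`, 2 nM
compound 2 `c1ccc(-c2ccncn2)c(OCC2=NCCN2)c1`, < 100000 nM
compound 3 `c1ccc(-c2nccs2)c(OCC2=NCCN2)c1`, 2.51 nM

In a functional assay for activation of Alpha-1A adrenergic receptor (Homo sapiens), read by calcium flux (on this read-out lower numbers stand for an effect already at smaller amounts and higher numbers for an effect only at larger amounts of compound), compound 1 gives 2 nM, the lowest of the two numbers read. Compound 3 sits nearest, with a 1.3-fold higher number from compound 1 to compound 3 (0.10 log units; within the scatter). For compound 2 the assay reports only a limit, < 100000 nM; because of the limit of < 100000 nM in this assay, at which 1 of the 3 values shown sits, the steps a step that the limit leaves unreadable from compound 1 to compound 2 and a step that the limit leaves unreadable from compound 2 to compound 3 cannot be read as numbers.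

Compound 4 `Cc1ccoc1-c1ccccc1OCC1=NCCN1` is not yet measured. It differs from compound 1 in one place: 3-methylfuran-2-yl in place of pyridin-3-yl on an aromatic carbon. For the measured compounds named here, the only readable step that bears on this change is the one to compound 3, where a five-membered aromatic ring with 1 hetero atom replaced pyridin-3-yl and gave a 1.3-fold higher number from compound 1 to compound 3 (0.10 log units; within the scatter). The unreadable step to compound 2 does not inform the estimate. For compound 4 the expected step is therefore a 1.5-fold higher number from compound 1 to compound 4 (0.18 log units; within the scatter), that is, no change beyond the scatter. The estimated value for compound 4 in this assay is 3 nM, with a range from 1 nM to 12 nM.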

Compound 4, half-maximal effective concentration: 3.16 nM
Compound 4: middle estimate off by 1.1-fold (0.02 log units), on the low side; the range from low to high includes it.
By their numbers in this assay, from the lowest: compounds 1, 3 and 4 (each within the scatter of the next).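

In this assay, the position on an aromatic carbon, ortho to a group of 7 heavy atoms, now also accepts 3-methylfuran-2-yl, an oxygen-containing five-membered aromatic ring carrying a methyl group, with a 1.6-fold higher number from compound 1 to compound 4 (0.20 log units; within the scatter). Against 1,3-thiazol-2-yl the change gives a 1.3-fold higher number from compound 3 to compound 4 (0.10 log units; within the scatter), so pyridin-3-yl, 1,3-thiazol-2-yl and 3-methylfuran-2-yl cannot be told apart in this series. Compound 2, with pyrimidin-4-yl, stands outside this reading, but its value is a limit and its steps cannot be read as numbers: the limit of < 100000 nM in this assay, at which 1 of the 4 values shown sits.

As far as these compounds go, what separates pyrimidin-4-yl from the other three rings remains open. Also open, from the compounds shown here alone, is whether the position holds this level with a non-aromatic group, such as an amine, a carboxylic acid or a longer chain, in place of the aromatic ring.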